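Exchanging the amide substituent: compound 2 to compound 3

This account rests on a few compounds, and the source may have more. Where it says the series, first, only, none or still open, it means among the compounds named here.

In a physicochemical assay for solubility, read by spectrophotometry, measured as kinetic solubility, at pH 8, tested at 500 uM (on this read-out lower numbers stand for lower solubility and higher numbers for higher solubility), compound 1 (`Cn1ccc2ccc(-c3cc(Nc4cnccc4C(=O)NCc4cncnc4)cc4nccnc34)cc21`) gives 233 ug/mL as its reading. Compound 2 (`CC(=O)N1CCC(NC(=O)c2ccncc2Nc2cc(-c3ccc4ccn(C)c4c3)c3nccnc3c2)CC1`) gives 213 ug/mL as its reading, so the two compounds stand level within the scatter, and neither separates from the other on these numbers.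

Compound 3 (`CN1CC(NC(=O)c2ccncc2Nc2cc(-c3ccc4ccn(C)c4c3)c3nccnc3c2)CCC1=O`) keeps the shared core and differs from compound 2 in one place: 1-methyl-6-oxopiperidin-3-yl in place of 1-acetylpiperidin-4-yl on an amide-type nitrogen is the full count of that change, with 1-methyl-6-oxopiperidin-3-yl in place of 1-acetylpiperidin-4-yl on an amide-type nitrogen.

Within the data shown here, only one measured step touches this position. The expectation rests on that single step, a 1.1-fold lower number from compound 1 to compound 2 (0.04 log units; within the scatter) being its size, where 1-acetylpiperidin-4-yl replaced (pyrimidin-5-yl)methyl and the reading stayed within the scatter. No measured exchange between two groups of this ring type exists in the series, so the guide is thin.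

No step beyond the scatter is expected in this assay here, and the estimated step is a 1.0-fold lower number from compound 2 to compound 3 (0.02 log units; within the scatter) in size. For compound 3 the estimate is 205 ug/mL with an expected range from 130 ug/mL to 250 ug/mL on this read-out.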

Compound 3, solubility: 253 ug/mL
Estimate against measurement, compound 3: 1.2-fold (0.09 log units) below; the measured number lies above the stated range.
By their numbers in this assay, from the lowest: compounds 2, 1 and 3 (each within the scatter of the next).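

In this assay, exchanging 1-acetylpiperidin-4-yl for 1-methyl-6-oxopiperidin-3-yl on the amide-type nitrogen gives a 1.2-fold higher number from compound 2 to compound 3 (0.07 log units; within the scatter) and is the only exchange shown between two groups of this ring type; moving the ring nitrogen and the carbonyl into a different arrangement, with one heavy atom fewer in the group, leaves the reading within the scatter. Set against the (pyrimidin-5-yl)methyl group, the same lactam-bearing ring gives a 1.1-fold higher number from compound 1 to compound 3 (0.04 log units; within the scatter), so the three substituents on this nitrogen now form a level set, with no pair separated on this read-out. Nothing available bears on why the readings stay level.

The compounds shown leave open whether this level behaviour extends beyond neutral carbonyl-bearing rings and the (pyrimidin-5-yl)methyl group, for instance to a piperidin-4-yl with a free ring amine or to a longer chain ending in a carboxylic acid. They also leave open whether the same exchange stays within the scatter when the shared core is changed elsewhere, since all three compounds carry that core unaltered.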